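The source may report more compounds than this note shows. Statements on the series, on what has been measured and on what is new or still open speak of the compounds shown alone.

Compound 2, `C=C1C(=O)N(c2ccccc2)N(C)C1C`, has no number yet in an ADME assay on HUVEC cells (Homo sapiens) for inhibition, read by MTT assay, with a stated time of 48 h; a lower number here means a stronger inhibitor, a higher number a weaker inhibitor: its entry reads "not determined" (no result reported), so it stands nowhere on that scale. For the measured compounds named here, the one measured neighbour of this shared core is compound 1, `C=CCC1C(=C)C(=O)N(c2ccccc2)N1c1ccccc1`, which in this assay gives 2730 nM; no step between compound 1 and compound 3 is available, so that number only shows roughly where this family has landed so far.

Compound 3, `C=C1C(=O)N(c2ccccc2)N(c2ccccc2)C1C`, differs from compound 2 in one place: phenyl in place of methyl on an amine nitrogen in a ring. Going by the values given here, with no value for compound 2, no step from compound 2 to compound 3 can be given, and no direction of change can be read from the data; what can be said is that compound 3 carries the same two phenyl groups on the ring nitrogens that compound 1 carries.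

On that basis, compound 3 is expected to give about 3000 nM in this assay, estimated to fall between 900 nM and 10000 nM.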

Compound 3, half-maximal inhibitory concentration: 29900 nM
The estimate for compound 3 lay 10-fold (1.00 log units) below the measured number; the whole stated range lies below it.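

In this assay, hydrogen in place of vinyl on a saturated chain carbon bound to a saturated ring carbon gives an 11-fold higher number from compound 1 to compound 3 (1.04 log units; beyond the scatter), which makes compound 3 the weaker inhibitor of the pair. The two phenyl groups shared by these compounds are therefore not enough to keep the number close to that of compound 1; the chain that ends in vinyl also counts in this assay. No measurement here explains why this change has so large an effect.

On these data alone, compound 2 has no number, so the step from it to compound 3 cannot be read, and the effect of phenyl in place of methyl on the ring nitrogen stays unknown. As far as these compounds go, it is also open whether the step follows the double bond of the vinyl or simply the length of the chain, a question that a saturated propyl chain in that place could settle.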